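The compounds below may be only part of what the source reports. "The series", "measured", "known", "first", "only" and "open" are said of these compounds alone.

Three compounds share a core and differ only at their edges. Compound 1 `CCn1c(-c2cnc(C)nc2)nc2c(O[C@H]3CCN(C(=O)C4CC4)C3)ncnc21` and compound 2 `CCC(=O)N1CC[C@H](Oc2ncnc3c2nc(-c2cnc(C)nc2)n3CC)C1` carry an oxygen between the core and the ring that bears the amide, while compound 3 `CCC(=O)N1CC[C@H](Nc2ncnc3c2nc(-c2cnc(C)nc2)n3CC)C1` carries a nitrogen there; the difference between the cores of compound 3 and compound 2 is not broken down here. In an ADME assay (Rattus norvegicus, strain Wistar Han) for pharmacokinetics (a lower number here means that more of the compound stays in the plasma, a higher number that more of the compound sits outside the plasma), compound 1 gives 0.7 L/kg, compound 2 gives 1.2 L/kg, and compound 3 gives 1 L/kg. Compound 3 and compound 2 sit within the usual scatter of each other, and so do compound 3 and compound 1.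

One change appears twice. From compound 2 to compound 1 it reads cyclopropyl in place of ethyl on a carbonyl carbon and made a step of a 1.7-fold lower number from compound 2 to compound 1 (0.23 log units; within the scatter). The same change leads from compound 3 to the unmeasured compound 4 `CCn1c(-c2cnc(C)nc2)nc2c(N[C@H]3CCN(C(=O)C4CC4)C3)ncnc21`: cyclopropyl in place of ethyl on a carbonyl carbon. The two changes sit at the same place, on a carbonyl carbon whose other neighbours are an amide-type nitrogen in a ring, so this is the same change, only on the core of compound 3 instead of the core of compound 2.

For compound 4 in this assay a step of a 1.4-fold lower number from compound 3 to compound 4 (0.15 log units; within the scatter) is expected, because the earlier step of a 1.7-fold lower number from compound 2 to compound 1 (0.23 log units; within the scatter) stayed within the scatter and compound 3 starts from 1 L/kg, close to compound 2. Compound 4 is therefore estimated at 0.7 L/kg, with a likely range from 0.4 L/kg to 1.2 L/kg.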

Compound 4, volume of distribution: 1 L/kg
The estimate for compound 4 lay 1.4-fold (0.15 log units) below the measured number, and the stated range covers the measured number.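

Cyclopropyl in place of ethyl on a carbonyl carbon was read a second time in this assay, and on the core of compound 3 it gave no change at the digits printed from compound 3 to compound 4 (within the scatter). Set beside its earlier reading, the change does not behave measurably differently on the two cores: the same change on two cores in this assay, a 1.7-fold lower number (0.23 log units; within the scatter) from compound 2 to compound 1 and no change at the digits printed (within the scatter) from compound 3 to compound 4, 1.7-fold (0.23 log units) apart, within the scatter of two such steps. In this small set, then, what was read for the change on the core of compound 2 held on the core of compound 3, in that neither step left the scatter and the two steps cannot be told apart. This does not show that the change has a real effect of its own on either core, and it does not show that the agreement extends past these two pairs, since a match of two small steps says little about how a larger one would carry over.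

The compounds shown leave open what a cyclobutyl group or a longer chain would do in the same place on the carbonyl carbon, and whether such a step would also read alike on both cores. They also leave open how a group of another kind, such as an amine or a carboxylic acid, would register in this assay on either core.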